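From 3-hydroxyphenyl to 3-methoxyphenyl: a small change

The source may report more compounds than this note shows. Statements on the series, on what has been measured and on what is new or still open speak of the compounds shown alone.

Compound 1 `CC1(C)[C@H]2CC[C@]1(C)N(Cc1cn(-c3ccc(F)cc3)nn1)C(=O)C2`: 40 nM
Compound 2 `CC1(C)[C@H]2CC[C@]1(C)N(Cc1cn(-c3ccc(Br)cc3)nn1)C(=O)C2`: 60 nM
Compound 3 `CC1(C)[C@H]2CC[C@]1(C)N(Cc1cn(-c3cccc(O)c3)nn1)C(=O)C2`: 410 nM

These values come from a functional assay on LoVo cells (Homo sapiens) for inhibition, read by MTT assay, with a stated time of 24 h; a higher number here means a weaker inhibitor, a lower number a stronger inhibitor. Compound 3 has the highest number of the three, which makes it the weakest inhibitor here. Compound 4 `COc1cccc(-n2cc(CN3C(=O)C[C@@H]4CC[C@@]3(C)C4(C)C)nn2)c1` keeps the shared core and differs from compound 3 at one point: methyl in place of hydrogen on an oxygen on an aromatic ring. Hydroxy thus becomes methoxy.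

Among the measured compounds shown here, no measured step makes this exact change. Fluoro and bromo barely separate: a 1.5-fold higher number from compound 1 to compound 2 (0.18 log units; within the scatter). Swapping the whole aromatic group matters more: a 10-fold higher number from compound 1 to compound 3 (1.01 log units; beyond the scatter) is large, and a 6.8-fold higher number from compound 2 to compound 3 (0.83 log units; beyond the scatter) is modest. Those swaps cannot isolate the hydroxy hydrogen, so the evidence is indirect.

Compound 4 changes less than either swap, and compound 3 at 410 nM has room to move toward compound 1 at 40 nM, so a smaller step to a lower number is expected in this assay. The expected step is a 2.7-fold lower number from compound 3 to compound 4 (0.44 log units; beyond the scatter). For compound 4 the estimated value is 150 nM, with an expected range of 50 nM to 450 nM.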

Compound 4, half-maximal inhibitory concentration: 80 nM
The estimate for compound 4 lay 1.9-fold (0.27 log units) above the measured number; the range from low to high includes it.
By their numbers in this assay, from the lowest: compounds 1, 2 and 4 (each within the scatter of the next); then compound 3.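

Adding one methyl to the oxygen of compound 3 isolates the hydroxy hydrogen, which the earlier swaps of the whole aromatic group could not do, and in this assay it gives (a 5.1-fold lower number from compound 3 to compound 4 (0.71 log units; beyond the scatter)). The 3-methoxyphenyl compound also sits within the scatter of both halogen compounds (a 1.3-fold higher number from compound 2 to compound 4 (0.12 log units; within the scatter); a 2.0-fold higher number from compound 1 to compound 4 (0.30 log units; within the scatter)), so among these four compounds only the 3-hydroxyphenyl group stands apart, and a substituent at that ring position does not by itself bring a weaker result. Nothing measured here explains why capping the hydroxy group has this effect.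

Going by these compounds, whether a larger group on the oxygen, such as ethoxy or a longer chain, would keep this level remains open. So does whether an amine in place of the hydroxy group, or a 4-hydroxyphenyl group, would behave like compound 3 or compound 4.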